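A few compounds are considered here, and "the series" means these few. Any claim that something is new, unique, unknown or untested is made for them only; others in the source may bear on it.

In an ADME assay for solubility (on this read-out higher numbers stand for higher solubility and lower numbers for lower solubility), compound 1 `Cc1c(C)c2c(c(C)c1O)CC(CCn1ccc(=O)c(O)c1C)O2` gives < 100 ug/mL and that is a limit of the assay, not a number. Compound 2 `Cc1c(C)c2c(c(C)c1OC(=O)CCN)CC(CCn1ccc(=O)c(O)c1C)O2` gives 10000 ug/mL as a true reading. Between these two lies an at least 100-fold higher number from compound 1 to compound 2 (2.00 log units; beyond the scatter) with (2-aminoethyl)carbonyl in place of hydrogen on an oxygen on an aromatic ring. Compound 3 `Cc1c(C)c2c(c(C)c1OC(=O)c1ccc(N)cc1)CC(CCn1ccc(=O)c(O)c1C)O2` gives < 100 ug/mL and this too is only a limit. The low end of the series is the limit of < 100 ug/mL in this assay, at which 2 of the 3 values shown sit, and compound 3 stands there. The reading for this pair is a step that the two limits leave unreadable from compound 1 to compound 3 and so tells nothing about size. The other measured step is clearer: an at least 100-fold lower number from compound 2 to compound 3 (2.00 log units; beyond the scatter) with 4-aminophenyl in place of 2-aminoethyl on a carbonyl carbon.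

Compound 4 `CNCC(=O)Oc1c(C)c(C)c2c(c1C)CC(CCn1ccc(=O)c(O)c1C)O2` comes next, and the difference is (methylamino)methyl in place of 4-aminophenyl on a carbonyl carbon with (methylamino)methyl in place of 4-aminophenyl on a carbonyl carbon. The 4-aminophenyl that entered in the large downward step from compound 2 now leaves, although the group that enters is not the one measured there. The estimated step is an at least 50-fold higher number from compound 3 to compound 4 (1.69 log units; beyond the scatter) and it is expected to be large, upward and beyond the scatter in this assay when read. Compound 4 is expected at 5000 ug/mL within an estimated range of 1000 ug/mL to 20000 ug/mL on this measure.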

Compound 4, solubility: > 20000 ug/mL
Compound 4 gave a limit, no number; the forecaster's own chance of this, stated with the estimate: 15%; middle value at least 4.0-fold (0.60 log units) from the limit.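

In this assay, a second group with no ring on this carbonyl carbon, (methylamino)methyl, separates clearly from 4-aminophenyl, with an at least 200-fold higher number from compound 3 to compound 4 (2.30 log units; beyond the scatter), and the ester as a whole separates just as clearly from hydrogen on the oxygen, with an at least 200-fold higher number from compound 1 to compound 4 (2.30 log units; beyond the scatter). The large gap to compound 3 is therefore no longer tied to 2-aminoethyl alone, since it now appears with two different chains on the same carbonyl carbon, and compound 3 is the one of these three esters that stays at the low end. The two chains themselves cannot be ranked, as the read-out gives an at least 2.0-fold higher number from compound 2 to compound 4 (0.30 log units; that floor lies within the scatter), and the series now has an upper bound as well as a lower one: the limit of > 20000 ug/mL in this assay, at which 1 of the 4 values shown sits.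

From the compounds shown here alone, how a chain ending in a carboxylic acid instead of an amine, or a longer chain carrying the amine, would read stays open. Also open, going by these compounds, is whether the reading of compound 3 goes with the aromatic ring as such, a question that a saturated ring such as piperidine on the same carbonyl carbon would address.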